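A few compounds are considered here, and "the series" means these few. Any claim that something is new, unique, unknown or untested is made for them only; others in the source may bear on it.

Among the compounds with values here, compound 2 `Cc1ccc(-c2cn(CCC3(O)NC(=O)C(OCc4ccccc4)=C3OCc3ccccc3)nn2)cc1` is the only compound here with a measured number: in a functional assay on PC-3 cells (Homo sapiens) for antiproliferative activity, read by MTT assay, with a stated time of 24 h (a lower number here means a stronger inhibitor, a higher number a weaker inhibitor), compound 2 gives 84200 nM. Compound 1 `Cc1ccc(-c2cn(C/C=C3\OC(=O)C(OCc4ccccc4)=C3OCc3ccccc3)nn2)cc1` is different: in this assay compound 1 gives > 100000 nM, which is a limit of the assay rather than a number. Compound 3 `CC(C)(C)c1ccc(-c2cn(CCC3(O)NC(=O)C(OCc4ccccc4)=C3OCc3ccccc3)nn2)cc1` differs from compound 2 in one place: tert-butyl in place of methyl on an aromatic carbon. Within the data shown here, no measured pair here carries such a change, so the data give no direction for it. The step from compound 2 to compound 3 is expected to stay within the usual scatter, at a 1.1-fold lower number from compound 2 to compound 3 (0.02 log units; within the scatter). Compound 3 is therefore estimated at 80000 nM, in a range from 30000 nM to 200000 nM.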

Compound 3, half-maximal inhibitory concentration: 43000 nM
Beside the measured number, compound 3's estimate is 1.9-fold (0.27 log units) above it; low and high end bracket the measured number.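

Within the data shown here, the change from 4-methylphenyl to 4-(tert-butyl)phenyl gives the first measured step at this position in this assay, a 2.0-fold lower number from compound 2 to compound 3 (0.29 log units; within the scatter). This position therefore accepts tert-butyl in place of methyl with no difference that can be told from the scatter. Nothing measured here explains the step.

Still open, from the compounds shown here alone, is whether a different group on this aromatic carbon, such as an amine or a carboxylic acid, would move the number beyond the scatter. Also open, going by these compounds, is whether this same change would read alike on a different core.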